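A few compounds are considered here, and "the series" means these few. Any claim that something is new, unique, unknown or untested is made for them only; others in the source may bear on it.

Of the compounds shown here, two from this series have been measured so far. Compound 1 `COc1cc(C(=O)c2sc(-c3ccc([N+](=O)[O-])cc3)cc2N)cc(OC)c1OC` gives 99 nM in a functional assay on CCRF-CEM cells (Homo sapiens) for antiproliferative activity; a lower number here means a stronger inhibitor, a higher number a weaker inhibitor. Compound 2 `COc1cccc(-c2cc(N)c(C(=O)c3cc(OC)c(OC)c(OC)c3)s2)c1` carries a 3-methoxyphenyl where compound 1 carries a 4-nitrophenyl, and in the same assay compound 2 gives 16 nM. Among the compounds with values here, that single change made a 6.2-fold lower number from compound 1 to compound 2 (0.79 log units; beyond the scatter), so compound 2 stands with the lowest number of the two, and compound 1 is the only other point of comparison.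

Compound 3 `COc1cc(C(=O)c2sc(-c3ccc(C(F)(F)F)cc3)cc2N)cc(OC)c1OC` has not yet been measured. Its change from compound 2 is 4-(trifluoromethyl)phenyl in place of 3-methoxyphenyl on an aromatic carbon. Within the data shown here, the one measured step that bears on this is the move from compound 1 to compound 2, which swapped one substituted phenyl group for another at the same position and shifted the number by a modest amount. Since the new group again carries no hydrogen-bond acceptor, like the nitrophenyl of compound 1 it is a departure from the best group seen, and a modest rise in the number is expected, roughly a 3.1-fold higher number from compound 2 to compound 3 (0.49 log units; beyond the scatter). Compound 3 is therefore estimated at 50 nM, with a likely range from 15 nM to 200 nM.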

Compound 3, half-maximal inhibitory concentration: 270 nM
Compound 3: the middle estimate sits 5.4-fold (0.73 log units) below what was measured; the whole stated range lies below it.
By their numbers in this assay, from the lowest: compound 2; then compound 1; then compound 3.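

Substituents on the phenyl ring at this position, next to the ring sulfur, matter more than the earlier pair showed: in this assay 4-(trifluoromethyl)phenyl in place of 3-methoxyphenyl gives a 17-fold higher number from compound 2 to compound 3 (1.23 log units; beyond the scatter) (a large step, and larger than the one seen before). The two groups that carry their substituent at the 4 place of the phenyl ring are not interchangeable either, since trifluoromethyl in place of nitro gives a 2.7-fold higher number from compound 1 to compound 3 (0.44 log units; beyond the scatter) (a modest step, but beyond the scatter). Nothing available here explains why these changes move the number as they do.

The compounds shown leave open whether the low number of compound 2 comes from the methoxy group itself or from where it sits on the phenyl ring, since the step from compound 2 to compound 3 changes both at once. From the compounds shown here alone, they also give no reference point for a plain phenyl ring without a substituent, or for a phenyl ring carrying an amine, so it remains unknown whether the trifluoromethyl and nitro groups raise the number or the methoxy group lowers it.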